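Chloro to methoxycarbonyl on the weakest compound so far

This account rests on a few compounds, and the source may have more. Where it says the series, first, only, none or still open, it means among the compounds named here.

Three compounds have numbers in a functional assay on MGC-803 cells (Homo sapiens) for inhibition, read by MTT assay, with a stated time of 48 h; a higher number here means a weaker inhibitor, a lower number a stronger inhibitor. Compound 1 (`C/C=C/C(=O)N(Cc1ccc(OC)c([N+](=O)[O-])c1)c1cc(OC)c(OC)c(OC)c1`) gives 590 nM, compound 2 (`COc1ccc(CN(C(C)=O)c2cc(OC)c(OC)c(OC)c2)cc1O`) gives 79 nM, and compound 3 (`COc1ccc(CNc2cc(OC)c(OC)c(OC)c2)cc1Cl`) gives 46200 nM. Compound 3 has the highest number of the three, beyond the scatter from both others, and is the weakest inhibitor measured so far. Compound 1 and compound 2 are amides, whereas compound 3 is not.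

The next compound is compound 4 (`COC(=O)c1cc(CNc2cc(OC)c(OC)c(OC)c2)ccc1OC`), also not an amide. It carries methoxycarbonyl in place of chloro on an aromatic carbon, ortho to a methoxy group: methoxycarbonyl in place of chloro on an aromatic carbon. Among the measured compounds shown here, no two measured compounds differ in only one place, so the series offers no measured step for this exchange, or for any other, in this assay. The closest guide is compound 3 at 46200 nM, and the expectation stays close to that value. The expected change, a 1.3-fold lower number from compound 3 to compound 4 (0.12 log units; within the scatter), is estimated to lie within the scatter, with no firm direction, although the uncertainty is wide. For compound 4 the estimated value is 35000 nM, with an expected range from 7000 nM to 100000 nM.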

Compound 4, half-maximal inhibitory concentration: 49600 nM
Estimate against measurement, compound 4: 1.4-fold (0.15 log units) below, and the stated range covers the measured number.
By their numbers in this assay, from the lowest: compound 2; then compound 1; then compounds 3 and 4 (each within the scatter of the next).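

In this assay the series now has its first step that can be read in one place, methoxycarbonyl in place of chloro on an aromatic carbon ortho to a methoxy group, and it is a 1.1-fold higher number from compound 3 to compound 4 (0.03 log units; within the scatter). At this position, methoxycarbonyl, with 4 heavy atoms and 2 hydrogen-bond acceptors, therefore stands in for chloro, with 1 heavy atom and 0 hydrogen-bond acceptors, without a change in the number beyond the scatter, though this is shown only for one pair of compounds that are not amides. No measured evidence bears on why the exchange leaves the number within the scatter.

Still open, on these data alone, is whether a carboxylic acid or a primary amine on this same aromatic carbon would shift the number in either direction. Steps from compound 1 or compound 2 to the other compounds cannot be read because they differ in more than one place, so it also remains open whether this exchange would give the same result on an amide.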